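Swapping chloro for fluoro on a hydrazone: an expectation

This account rests on a few compounds, and the source may have more. Where it says the series, first, only, none or still open, it means among the compounds named here.

Measured so far in an ADME assay on J774 cells (Mus musculus) for cytotoxicity, read by MTT assay, with a stated time of 48 h, tested at 100 ug/mL; a lower number here means a stronger effect, a higher number a weaker effect of the compound at the concentration tested:
compound 1 `O=C(N/N=C/c1ccccc1Cl)c1cnccn1` gives 66%
compound 2 `O=C(N/N=C/c1ccc(Cl)cc1)c1cnccn1` gives 64%
compound 3 `O=C(N/N=C/c1ccccc1F)c1cnccn1` gives 100%

The cores of compound 1 and compound 2 hold the same atoms joined differently; the difference between the two cores is not broken down here. The change from compound 1 to compound 3 is fluoro in place of chloro on an aromatic carbon, and in this assay it made a step of a number 34 percentage points higher from compound 1 to compound 3 (beyond the scatter). Compound 4 `O=C(N/N=C/c1ccc(F)cc1)c1cnccn1` differs from compound 2 by fluoro in place of chloro on an aromatic carbon, the same kind of change, though the place differs: ortho to a large group in the first pair, para to a large group in the second. The step from compound 2 to compound 4 is expected to be a number 28 percentage points higher from compound 2 to compound 4 (beyond the scatter), resting on the step of a number 34 percentage points higher from compound 1 to compound 3 (beyond the scatter). Compound 4 is therefore estimated at 92%, between 70% and 100%.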

Compound 4, a percentage reported as activity, at one concentration (the size of the read-out at that concentration, not a potency): 69%
The estimate for compound 4 lay 23 percentage points above the measured number, and the stated range ends above it.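

In this assay, fluoro in place of chloro, para to a large group, gives a small step: a number 5 percentage points higher from compound 2 to compound 4 (within the scatter). The change therefore does not carry from one core to the other as a fixed number in this small series: the same change on two cores in this assay, a number 34 percentage points higher (beyond the scatter) from compound 1 to compound 3 and a number 5 percentage points higher (within the scatter) from compound 2 to compound 4, 29 percentage points apart, beyond the scatter of two such steps This shows that the size of the step depends on the pair of compounds, but it does not show why, and with a single pair for each place the data cannot say whether the same difference would recur on other pairs.

The compounds shown hold only chloro or fluoro on this ring. Going by these compounds, how a bromo, a methoxy or an amine in the same places would read in this assay remains open.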